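Series notes: aryl thioether replacing benzylamino on the shared core

The source may hold more compounds than are shown below. What is called first, only, known or untested is meant among the compounds shown, and "the series" means these compounds.

compound 1 `COc1ccc(CNc2nc3cc(N)cc(N)c3nc2-c2ccccc2)cc1OC` — < 100000 nM
compound 2 `Nc1cc(N)c2nc(-c3ccccc3)c(NCc3ccc(F)cc3)nc2c1` — < 100000 nM

In a functional assay on Hs-578T cells (Homo sapiens) for inhibition, read by sulforhodamine B assay, with a stated time of 48 h (a higher number here means a weaker inhibitor of growth, a lower number a stronger inhibitor of growth), compound 1 gives only a limit, < 100000 nM. Compound 2 likewise gives only a limit, < 100000 nM. Going by the values given here, the one measured step, a step that the two limits leave unreadable from compound 1 to compound 2, touches a different part of the molecule and its size is not readable. Compound 2 therefore stands at the limit of < 100000 nM in this assay, at which 2 of the 2 values shown sit, with nothing to separate it from compound 1. Compound 3 `Nc1cc(N)c2nc(-c3ccccc3)c(Sc3ccc(F)cc3)nc2c1` introduces ((4-fluorophenyl)sulfanyl in place of (4-fluorobenzyl)amino on an aromatic carbon). Among the compounds with values here, no measured step bears on this change, so the expected step that the limit leaves unreadable from compound 2 to compound 3 is undetermined in direction. Compound 3 is estimated at 20000 nM, within 3000 nM to 100000 nM.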

Compound 3, concentration for total growth inhibition: 61700 nM
For compound 3 the middle estimate is 3.1-fold (0.49 log units) below the measured one, and the stated range covers the measured number.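

No step from compound 2 to compound 3 can be read in this assay, because compound 2 gives only a limit: the limit of < 100000 nM in this assay, at which 2 of the 3 values shown sit.
As far as these compounds go, whether (4-fluorophenyl)sulfanyl in place of (4-fluorobenzyl)amino strengthens or weakens growth inhibition stays open.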